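The source may report more compounds than this note shows. Statements on the series, on what has been measured and on what is new or still open speak of the compounds shown alone.

Measured so far in a physicochemical assay for solubility, read by HPLC, in phosphate buffer, measured as kinetic solubility, with a stated time of 24 h, at 20 degrees C, at pH 7.4, tested at 100 uM; a lower number here means a less soluble compound, a higher number a more soluble compound:
Compound 1, `Cc1nc(N)nc2c1c(-c1ccc3oc(N)nc3c1)nn2C(C)C`: 74000 nM.
Compound 2, `COc1nc(N)nc2c1c(-c1ccc3oc(N)nc3c1)nn2C(C)C`: < 1000 nM; this is a limit of this assay and not a number.

Compound 2 therefore stands at the limit of < 1000 nM in this assay, at which 1 of the 2 values shown sits, and only a limit is known for it. Among the compounds with values here, the single measured step, an at least 74-fold lower number from compound 1 to compound 2 (1.86 log units; beyond the scatter), is large and runs downward. Compound 3, `CC(C)n1nc(-c2ccc3oc(N)nc3c2)c2c(F)nc(N)nc21`, differs from compound 2 by fluoro in place of methoxy on an aromatic carbon. Within the data shown here, the measured step concerns methyl against methoxy and so bears on this change only indirectly; no measured step covers fluoro at this place. The expectation rests on the gap between compound 1 and the limit of compound 2 alone. For compound 3 a rise beyond the scatter in this assay is expected, an at least 8.0-fold higher number from compound 2 to compound 3 (0.90 log units; beyond the scatter), with no firmer anchor than that. The estimate for compound 3 in this assay is 8000 nM, with a range from 1000 nM to 60000 nM; a reading at the limit remains possible.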

Compound 3, solubility: < 1000 nM
Compound 3: a limit, no number; the forecaster's own chance of this, stated with the estimate: 30%; middle value at least 8.0-fold (0.90 log units) from the limit.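

In this assay, fluoro in place of methyl on this aromatic carbon next to the ring nitrogen gives an at least 74-fold lower number from compound 1 to compound 3 (1.86 log units; beyond the scatter), so the large drop is no longer seen with methoxy alone. Compound 3 carries < 1000 nM, which is a limit of the assay and not a number. Methyl remains the only group at this place with a readable value, and the step between the two methoxy and fluoro compounds cannot be read: the limit of < 1000 nM in this assay, at which 2 of the 3 values shown sit.

On these data alone, how far compound 2 and compound 3 each lie from their shared limit stays open, so methoxy and fluoro cannot be ordered against each other. Also open, as far as these compounds go, is whether an ethyl group, a chloro group or an amine on this carbon would give a readable number in this assay, as compound 1 does with 74000 nM.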